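A few compounds are considered here, and "the series" means these few. Any claim that something is new, unique, unknown or untested is made for them only; others in the source may bear on it.

Measured so far:
compound 1 `COc1ccc(C(=O)Nc2ccccc2C)cc1OC1CCCC1`, in an assay on isolated protein for inhibition of phosphodiesterase 4A (Sus scrofa); a higher number here means a weaker inhibitor, a lower number a stronger inhibitor: 300 nM
compound 2 `COc1ccc(C(=O)Nc2ccccn2)cc1OC1CCCC1`: 1000 nM

Within the data shown here, compound 2 stands at the higher of the two numbers; the only measured step is a 3.3-fold higher number from compound 1 to compound 2 (0.52 log units; beyond the scatter). Compound 3 `COc1ccc(C(=O)Nc2ncccc2C)cc1OC1CCCC1` differs from compound 2 by methyl in place of hydrogen on an aromatic carbon. This restores a methyl on the ring that compound 1 carries as 2-methylphenyl, so the step of a 3.3-fold higher number from compound 1 to compound 2 (0.52 log units; beyond the scatter) bears on it in reverse, and a partial return toward the number of compound 1 is expected, a step of a 2.2-fold lower number from compound 2 to compound 3 (0.35 log units; beyond the scatter). Compound 3 is therefore estimated at 450 nM, with a range from 200 nM to 1000 nM.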

Compound 3, half-maximal inhibitory concentration: 3100 nM
For compound 3 the middle estimate is 6.9-fold (0.84 log units) below the measured one, outside the stated range (above it).
By their numbers in this assay, from the lowest: compound 1; then compound 2; then compound 3.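

In this assay, methyl on the aromatic carbon ortho to a large group, two atoms from the ring nitrogen, gives a 3.1-fold higher number from compound 2 to compound 3 (0.49 log units; beyond the scatter), so on the pyridin-2-yl ring it does not bring the number back toward that of the 2-methylphenyl amide. With the methyl present on both rings, the ring nitrogen comes with a 10-fold higher number from compound 1 to compound 3 (1.01 log units; beyond the scatter), a large step, so the methyl does not carry the same outcome across the two rings. No available evidence accounts for either step. Open, going by these compounds, is whether fluorine or an ethyl chain on this carbon gives a similar rise.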